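Swapping piperidine for morpholine on an iodinated adenosine nucleoside

This account rests on a few compounds, and the source may have more. Where it says the series, first, only, none or still open, it means among the compounds named here.

Measured compounds:
- compound 1, `OC[C@H]1OC(n2cnc3c(NN4CCOCC4)ncnc32)[C@H](O)[C@@H]1O`, 15500 nM
- compound 2, `OC[C@H]1OC(n2cnc3c(NN4CCCCC4)nc(I)nc32)[C@H](O)[C@@H]1O`, 71 nM

In an assay on membranes from brain for binding affinity to adenosine receptor A1 (Rattus norvegicus) (on this read-out lower numbers stand for stronger inhibition and higher numbers for weaker inhibition), compound 2 gives the lowest of the two numbers; compound 1 sits far higher, beyond the scatter, but the two differ in two places, so the two values alone do not separate the effects. Compound 3, `OC[C@H]1OC(n2cnc3c(NN4CCOCC4)nc(I)nc32)[C@H](O)[C@@H]1O`, isolates one of them: morpholin-4-yl in place of piperidin-1-yl on a nitrogen on an aromatic ring. For the measured compounds named here, no measured pair shows this single change, so the direction is uncertain; a modest weakening is expected, with a 5.6-fold higher number from compound 2 to compound 3 (0.75 log units; beyond the scatter). Compound 3 is therefore estimated at 400 nM, within 100 nM to 2000 nM.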

Compound 3, inhibition constant: 113 nM
Beside the measured number, compound 3's estimate is 3.5-fold (0.55 log units) above it; low and high end bracket the measured number.
By their numbers in this assay, from the lowest: compounds 2 and 3 (each within the scatter of the next); then compound 1.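

In this assay, morpholin-4-yl in place of piperidin-1-yl on a nitrogen on an aromatic ring gives a 1.6-fold higher number from compound 2 to compound 3 (0.20 log units; within the scatter) and so, with iodo present, this swap cannot be told apart from no change. Iodo in place of hydrogen on an aromatic carbon gives a 140-fold lower number from compound 1 to compound 3 (2.14 log units; beyond the scatter) and is the only single change shown that moves the number beyond the scatter. No supporting measurement accounts for either result. On these data alone, whether the ring swap stays this small on the core without iodo remains open. So does whether chloro or an amine in the place of iodo would give a similarly low number.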